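Trifluoromethyl on the Phenyl Ring: From Compound 3 to Compound 4

This account rests on a few compounds, and the source may have more. Where it says the series, first, only, none or still open, it means among the compounds named here.

The measured compounds and their values:
compound 1, `CCOC(=O)/C(C#N)=C/c1cc(C)n(-c2cccc(-c3nnn[nH]3)c2)c1C`, gives 76800 nM
compound 2, `CCOC(=O)C(=Cc1cc(C)n(-c2cccc(-c3nnn[nH]3)c2)c1C)C(=O)OCC`, gives 77400 nM
compound 3, `Cc1cc(/C=C2\SC(=S)N(c3ccccc3)C2=O)c(C)n1-c1cccc(-c2nnn[nH]2)c1`, gives 61000 nM

All three values come from an ADME assay on MT2 cells (Homo sapiens) for cytotoxicity, read by XTT assay, with a stated time of 4 days; on this read-out higher numbers stand for lower toxicity in this test and lower numbers for higher toxicity in this test. On these numbers compound 3 holds the lowest value of the three, but its gap to compound 1 and to compound 2 lies within the usual scatter of repeated measurements, so no order among the three can be read from them; the set describes a narrow band rather than a ranking.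

Compound 4, `Cc1cc(/C=C2\SC(=S)N(c3cccc(C(F)(F)F)c3)C2=O)c(C)n1-c1cccc(-c2nnn[nH]2)c1`, has not yet been measured in this assay. It differs from compound 3 in one place: trifluoromethyl in place of hydrogen on an aromatic carbon. For the measured compounds named here, the change sits on an aromatic carbon of a six-membered aromatic ring of carbon only, and the pair of measured compounds offers no step of the same kind to lean on.

Going by the values given here, with no comparable step among the measured compounds, the step expected from compound 3 to compound 4 in this assay, a 1.1-fold lower number from compound 3 to compound 4 (0.04 log units; within the scatter), is estimated to stay within the scatter, with no clear direction. On that basis compound 4 is expected to give about 55000 nM, within a range of 25000 nM to 120000 nM.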

Compound 4, half-maximal cytotoxic concentration: 15800 nM
The estimate for compound 4 lay 3.5-fold (0.54 log units) above the measured number; measured number below the stated range.
By their numbers in this assay, from the lowest: compound 4; then compounds 3, 1 and 2 (each within the scatter of the next).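

In this assay, the phenyl ring of compound 3 proves not to be a silent place: trifluoromethyl in place of hydrogen on an aromatic carbon, meta to a large group, gives a 3.9-fold lower number from compound 3 to compound 4 (0.59 log units; beyond the scatter), a step that lies beyond the scatter. For the compounds shown here, the earlier compounds offered no step at a single place, so this pair is the only direct evidence that a change on this ring can move the number, and here it moves towards higher toxicity in this test. Nothing measured here accounts for the step, which stands as an observation on one pair, with no cause attached.

The compounds shown leave open whether a chlorine atom, a methoxy group or an amine at the same place would move the number in the same direction or by a similar amount. They also leave open whether trifluoromethyl at another carbon of that ring would give a comparable step, so a single pair cannot yet say how far the effect depends on the group or on its place.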